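Dropping the chloro from a sulfonyl carbamate

The compounds below may be only part of what the source reports. "The series", "measured", "known", "first", "only" and "open" are said of these compounds alone.

Values measured in a functional assay on MDA-MB-231 cells (Homo sapiens) for antiproliferative activity, read by MTT assay, with a stated time of 96 h (on this read-out higher numbers stand for weaker inhibition and lower numbers for stronger inhibition), so far
- Compound 1 `CC(C)=CCC/C(C)=C/CC/C(C)=C/CC[C@]1(C)CCc2c(C)c(OC(=O)NS(=O)(=O)c3ccccc3)c(C)c(C)c2O1` gives > 10000 nM as a limit
- Compound 2 `CC(C)=CCC/C(C)=C/CC/C(C)=C/CC[C@]1(C)CCc2cc(OC(=O)NS(=O)(=O)c3ccc(Cl)cc3)c(C)c(C)c2O1` gives > 10000 nM as a limit

Within the data shown here, neither entry is a number, and the series so far stands at the limit of > 10000 nM in this assay, at which 2 of the 2 values shown sit, in full. Compound 2 therefore has no exact position, only its limit of > 10000 nM in this assay to mark where it stands.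

Compound 3 `CC(C)=CCC/C(C)=C/CC/C(C)=C/CC[C@]1(C)CCc2cc(OC(=O)NS(=O)(=O)c3ccccc3)c(C)c(C)c2O1` keeps the rest of compound 2 and differs from it in one place, with hydrogen in place of chloro on an aromatic carbon as the counted change. Hydrogen takes the place of chloro on an aromatic carbon, para to a large group, so that 4-chlorophenyl becomes phenyl.

Among the measured compounds shown here, no measured pair isolates this exchange. No step beyond the usual scatter is expected in this assay, in either direction, and a further limit is the likeliest report. The expectation rests on compound 2 and its limit of > 10000 nM in this series. The expected change is a step that the limit leaves unreadable from compound 2 to compound 3 and should not be read as a real shift. Compound 3 is estimated at 12000 nM in an expected range from 5000 nM to 30000 nM in this read-out.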

Compound 3, half-maximal inhibitory concentration: > 10000 nM
Compound 3 ended at the assay's limit (the forecaster's own chance of this, stated with the estimate: 80%); the middle value is on the limit's open side.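

No step can be read between compound 3 and either compound 2 or compound 1 in this assay, since all three entries are limits and not numbers: the limit of > 10000 nM in this assay, at which 3 of the 3 values shown sit.

The compounds shown leave open whether hydrogen in place of chloro or methyl on an aromatic carbon changes the read-out at all, and how far any of these compounds lies past the limit.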